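Aryloxy swap across two pentafluorosulfanyl anilide cores

The source may report more compounds than this note shows. Statements on the series, on what has been measured and on what is new or still open speak of the compounds shown alone.

Compound 1 `CC(O)(COc1cccc(C(F)(F)F)c1)C(=O)Nc1ccc(S(F)(F)(F)(F)F)cc1` and compound 2 `CC(O)(COc1ccccc1C(F)(F)F)C(=O)Nc1ccc(S(F)(F)(F)(F)F)cc1` share one core and differ only in the aryl group on the ether oxygen. In a functional assay on DU-145 cells (Homo sapiens) for antiproliferative activity, read by propidium iodide staining, with a stated time of 96 h (on this read-out lower numbers stand for stronger inhibition and higher numbers for weaker inhibition), compound 1 gives 21900 nM and compound 2 gives 7100 nM. The change between them is 2-(trifluoromethyl)phenyl in place of 3-(trifluoromethyl)phenyl on an oxygen on a saturated carbon, and it made the step of a 3.1-fold lower number from compound 1 to compound 2 (0.49 log units; beyond the scatter).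

Compound 3 `CC(O)(COc1cccc(C(F)(F)F)c1)C(=O)Nc1cccc(S(F)(F)(F)(F)F)c1` carries a second core; how it differs from compound 1 is not broken down here. In this assay compound 3 gives 31700 nM, which sits within the scatter of compound 1 and beyond it from compound 2.

Compound 4 `CC(O)(COc1ccccc1C(F)(F)F)C(=O)Nc1cccc(S(F)(F)(F)(F)F)c1` is not yet measured. It differs from compound 3 by 2-(trifluoromethyl)phenyl in place of 3-(trifluoromethyl)phenyl on an oxygen on a saturated carbon, the same change at the same place as that from compound 1 to compound 2. Within the data shown here, the expected step is therefore taken as a 3.0-fold lower number from compound 3 to compound 4 (0.48 log units; beyond the scatter), resting on the single earlier step of a 3.1-fold lower number from compound 1 to compound 2 (0.49 log units; beyond the scatter), with wide bounds since only one instance exists. Compound 4 is expected in this assay at about 10500 nM, between 4500 nM and 26000 nM.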

Compound 4, half-maximal inhibitory concentration: 52200 nM
Beside the measured number, compound 4's estimate is 5.0-fold (0.70 log units) below it; the measured number lies above the stated range.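

In this assay, 2-(trifluoromethyl)phenyl in place of 3-(trifluoromethyl)phenyl on an oxygen on a saturated carbon does not carry over between the two cores. The step on the second core is a 1.6-fold higher number from compound 3 to compound 4 (0.22 log units; within the scatter), and the two steps differ: the same change on two cores in this assay, a 3.1-fold lower number (0.49 log units; beyond the scatter) from compound 1 to compound 2 and a 1.6-fold higher number (0.22 log units; within the scatter) from compound 3 to compound 4, 5.1-fold (0.71 log units) apart, beyond the scatter of two such steps

The lower number seen on the core of compound 1 therefore cannot be assumed for the core of compound 3, where the two aryl groups stay within the scatter of each other. With one pair per core, this shows that the outcome of this one change depends on the core, but it gives no reason for that dependence and no rule for other aryl groups.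

Going by these compounds, it remains open whether a phenyl carrying a nitrile or a chlorine in place of trifluoromethyl would behave on the two cores as these aryl groups do. On these data alone, it is also open whether an amine in place of the ether oxygen would leave the two cores apart in the same way.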